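Swapping a methylphenyl for a nitrophenyl on the amide

A few compounds are considered here, and "the series" means these few. Any claim that something is new, unique, unknown or untested is made for them only; others in the source may bear on it.

Compound 1 `NC(=O)c1c(NC(=O)c2ccccc2Cl)sc2c1CCN(Cc1c(Cl)cccc1Cl)C2` and compound 2 `Cc1ccc(C(=O)Nc2sc3c(c2C(N)=O)CCN(Cc2c(Cl)cccc2Cl)C3)cc1` share one core and differ only in the aryl group on the amide carbonyl. In a functional assay on HeLa cells (Homo sapiens) for antiproliferative activity, with a stated time of 24 h (on this read-out higher numbers stand for weaker inhibition and lower numbers for stronger inhibition), compound 1 gives 28800 nM, and in this assay compound 2 gives 47400 nM. The step of a 1.6-fold higher number from compound 1 to compound 2 (0.22 log units; within the scatter) shows that the two numbers lie within the usual scatter of each other. Compound 3 `NC(=O)c1c(NC(=O)c2cccc([N+](=O)[O-])c2)sc2c1CCN(Cc1c(Cl)cccc1Cl)C2` carries the change (3-nitrophenyl in place of 4-methylphenyl on a carbonyl carbon). Within the data shown here, only that one measured step bears on this exchange, and it stayed within the scatter, so the expected step is a 1.4-fold lower number from compound 2 to compound 3 (0.13 log units; within the scatter). Compound 3 is therefore estimated at 35000 nM in this assay, within 12000 nM to 100000 nM.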

Compound 3, half-maximal inhibitory concentration: 46100 nM
Compound 3: middle estimate off by 1.3-fold (0.12 log units), on the low side; the measured number falls inside the stated range.
By their numbers in this assay, from the lowest: compounds 1, 3 and 2 (each within the scatter of the next).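

In this assay, the exchange of 4-methylphenyl for 3-nitrophenyl gives a 1.0-fold lower number from compound 2 to compound 3 (0.01 log units; within the scatter) on this carbonyl carbon, and the exchange of 2-chlorophenyl for 3-nitrophenyl gives a 1.6-fold higher number from compound 1 to compound 3 (0.20 log units; within the scatter) at the same place. The entering group brings nitrogen, oxygen and two hydrogen-bond acceptors, yet all three aryl groups now sit within the scatter of each other, so this position has not separated them. Still open, on these data alone, is whether a group of another kind here, such as an amine, a carboxylic acid or a longer alkyl chain in place of the aryl ring, would give a step beyond the scatter. No measurement shown gives a reason for these close values.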